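Aryl exchange from compound 3 to compound 4

This account rests on a few compounds, and the source may have more. Where it says the series, first, only, none or still open, it means among the compounds named here.

Measured in a functional assay (muscle tissue) with Cavia porcellus as the target; on this read-out lower numbers stand for an effect already at smaller amounts and higher numbers for an effect only at larger amounts of compound:
- compound 1 `COC(=O)C1=C(C)N=C(C)/C(=C(\O)OC)C1c1ccccc1N`: 39800 nM
- compound 2 `COC(=O)C1=C(C)N=C(C)/C(=C(\O)OC)C1c1cccc(N)c1`: 2000 nM
- compound 3 `COC(=O)C1=C(C)N=C(C)/C(=C(\O)OC)C1c1ccc(I)cc1`: 22900 nM

Compound 3 groups with compound 1 at the high end of these numbers. The two steps that place it are a 1.7-fold lower number from compound 1 to compound 3 (0.24 log units; within the scatter) and an 11-fold higher number from compound 2 to compound 3 (1.06 log units; beyond the scatter).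

The unmeasured compound 4 `CCc1ccccc1C1C(C(=O)OC)=C(C)N=C(C)/C1=C(\O)OC` carries 2-ethylphenyl in place of 4-iodophenyl on a saturated ring carbon.

Exchanging the aryl group has given both outcomes: a large step in a 20-fold lower number from compound 1 to compound 2 (1.30 log units; beyond the scatter), but none beyond the scatter in a 1.7-fold lower number from compound 1 to compound 3 (0.24 log units; within the scatter). The nearest measured group is the 2-aminophenyl of compound 1, at 39800 nM. No step beyond the scatter is therefore expected in this assay, although a large one remains possible. The expected step is a 1.1-fold lower number from compound 3 to compound 4 (0.06 log units; within the scatter). Compound 4 is estimated at 20000 nM, with an expected range of 5000 nM to 60000 nM.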

Compound 4, half-maximal effective concentration: 6.46 nM
The estimate for compound 4 lay 3100-fold (3.49 log units) above the measured number; measured number outside the range, below it.
By their numbers in this assay, from the lowest: compound 4; then compound 2; then compounds 3 and 1 (each within the scatter of the next).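

Working notes: in this assay the aryl position on the saturated ring carbon reaches far lower numbers than the earlier groups suggested, with 2-ethylphenyl giving a 3500-fold lower number from compound 3 to compound 4 (3.55 log units; beyond the scatter) and a 310-fold lower number from compound 2 to compound 4 (2.49 log units; beyond the scatter). The group on the aromatic carbon counts as well as its place, as ethyl in place of amino gives a 6200-fold lower number from compound 1 to compound 4 (3.79 log units; beyond the scatter). Nothing measured here explains these steps.

Open, from the compounds shown here alone, is whether methyl or a longer chain such as propyl in place of ethyl keeps the low number. Also open, going by these compounds, is whether ethyl keeps it elsewhere on the phenyl ring.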